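A few compounds are considered here, and "the series" means these few. Any claim that something is new, unique, unknown or untested is made for them only; others in the source may bear on it.

Measured so far:
compound 1 `CCOC(=O)c1cnc2ccc(-c3cnc(OC)c(NS(=O)(=O)c4ccc(F)cc4F)c3)cn12` — in a functional assay on SNU-638 cells (Homo sapiens) for antiproliferative activity, read by sulforhodamine B assay, with a stated time of 72 h (a lower number here means a stronger inhibitor, a higher number a weaker inhibitor), compound 1 gives 360 nM
compound 2 `COc1ncc(-c2ccc3ncc(C(=O)O)n3c2)cc1NS(=O)(=O)c1ccc(F)cc1F` — in this assay compound 2 gives 1460 nM

Among the measured compounds shown here, compound 1 holds the lowest of the two numbers; its nearest neighbour is compound 2, at a 4.1-fold higher number from compound 1 to compound 2 (0.61 log units; beyond the scatter), with hydrogen in place of ethyl on an oxygen next to a carbonyl group as the only change.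

Compound 3 `CCOC(=O)c1cnc2ccc(-c3cnc(OC)c(NS(=O)(=O)c4ccc(F)cc4)c3)cn12` differs from compound 1 by hydrogen in place of fluoro on an aromatic carbon, the difference reading 2,4-difluorophenyl to 4-fluorophenyl on the sulfonyl. For the measured compounds named here, the single measured step, from ester to acid, lies on the other end of the molecule and does not bear on this change; no measured pair speaks to the sulfonyl aryl. The step is therefore expected to be small, likely within the scatter, with a slight lean toward a higher number. Compound 3 is expected to give 500 nM, range 200 nM to 1300 nM, which means a 1.4-fold higher number from compound 1 to compound 3 (0.14 log units; within the scatter).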

Compound 3, half-maximal inhibitory concentration: > 20000 nM
Compound 3: a limit, no number (the forecaster's own chance of this, stated with the estimate: 2%); middle value at least 40-fold (1.60 log units) from the limit.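

In this assay compound 3 gives > 20000 nM, which is a limit of the assay and not a number. The change from 2,4-difluorophenyl to 4-fluorophenyl gives an at least 55-fold higher number from compound 1 to compound 3 (1.74 log units; beyond the scatter), so a single fluoro, ortho to a large group and meta to a fluoro group, separates measurable activity from a reading at the limit: the limit of > 20000 nM in this assay, at which 1 of the 3 values shown sits.

Among the compounds shown here, the sulfonyl aryl therefore proves far less tolerant of this change than the ester end of the molecule, where the only other measured change gives a 4.1-fold higher number from compound 1 to compound 2 (0.61 log units; beyond the scatter).

Going by these compounds, whether a chloro or a methyl group at this place would hold the activity of compound 1 remains open. Also open, on these data alone, are the effect of replacing the remaining fluoro with hydrogen and whether the same loss would appear in the carboxylic acid series.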